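Configuration change at two ring carbons, compound 1 to compound 4

This account rests on a few compounds, and the source may have more. Where it says the series, first, only, none or still open, it means among the compounds named here.

Results so far in a functional assay on A549 cells (Homo sapiens) for cytotoxicity, read by MTT assay (a lower number here means a stronger inhibitor, a higher number a weaker inhibitor), are these:
- compound 1 (`COC(=O)C[C@@H]1C[C@@H](O)[C@H](C)[C@H](c2ccccc2)N1`): 8500 nM
- compound 2 (`COC(=O)C[C@H]1C[C@@H](O)[C@@H](C)[C@@H](c2ccc(C(C)C)cc2)N1`): "not active" (no number reported)
- compound 3 (`COC(=O)C[C@H]1C[C@H](O)[C@@H](C)[C@@H](c2ccc(C(C)C)cc2)N1`): "not active" (no number reported)

Among the measured compounds shown here, compound 1 holds the only number in this set (8500 nM) and so has no numerical rank against another compound. Compound 2 and compound 3 carry no number. Their shared outcome stands alongside the fact that compounds 2 and 3 differ only in the configuration as drawn and gives no size for a change of configuration.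

Compound 4 (`COC(=O)C[C@H]1C[C@@H](O)[C@H](C)[C@@H](c2ccccc2)N1`) has no result yet in this assay and is the next point of comparison. Structurally, the two compounds have the same atoms and bonds and differ only in configuration as drawn: 2 of 4 stereo elements differ; a stereocentre at a saturated ring carbon is drawn S in compound 1 and R in compound 4; a stereocentre at a saturated ring carbon is drawn R in compound 1 and S in compound 4 and no group is exchanged.

For the measured compounds named here, no step between measured compounds is available to scale this change, so the expectation is loose. It leans towards weaker inhibition, a moderate step slightly beyond the usual scatter, on the thin support that compound 2 gives "not active" (no number reported) and compound 3 gives "not active" (no number reported) in this assay even though neither is a direct match. A report without a number is also a real possibility. The expected move is a 2.4-fold higher number from compound 1 to compound 4 (0.37 log units; beyond the scatter) as an estimate only. For compound 4 the estimated value is 20000 nM with an expected range from 6000 nM to 70000 nM in this assay.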

Compound 4, half-maximal inhibitory concentration: 34600 nM
The estimate for compound 4 lay 1.7-fold (0.24 log units) below the measured number; the range from low to high includes it.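

In this assay the inversion at two saturated ring carbons gives a 4.1-fold higher number from compound 1 to compound 4 (0.61 log units; beyond the scatter), the first numerical size for a change of configuration in this series, which compounds 2 and 3 could not supply with no number for either. The step can be assigned to configuration alone, because no group is exchanged and the atoms and bonds stay the same: the fact that compounds 1 and 4 differ only in the configuration as drawn. Both phenyl compounds return a number, so this change moves the read-out towards weaker inhibition without ending it.

Which of the two ring carbons carries the step stays open, since both inversions arrive together and no compound shown inverts one of them alone with the phenyl group in place. Also open, on these data alone, is whether a change of configuration has a step of similar size when the methyl ester gives way to a carboxylic acid or an amide, or when the hydroxyl gives way to an amine.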